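Swapping one five-membered azole for another at the para position

A few compounds are considered here, and "the series" means these few. Any claim that something is new, unique, unknown or untested is made for them only; others in the source may bear on it.

Compound 2 `CCCN(CC[C@H]1CC[C@H](NC(=O)c2ccc(-n3cccn3)cc2)CC1)[C@H]1CCc2nc(N)sc2C1` gives 3 nM in an assay on brain for displacement of a labelled ligand from D(3) dopamine receptor (Rattus norvegicus); on this read-out lower numbers stand for stronger inhibition and higher numbers for weaker inhibition. Compound 1 `CCCN(CC[C@H]1CC[C@H](NC(=O)c2ccc(-n3ccnc3)cc2)CC1)[C@H]1CCc2nc(N)sc2C1` gives 1.9 nM, and the two numbers lie within the usual scatter of each other, so compound 2 stands alongside compound 1 rather than apart from it. Compound 3 `CCCN(CC[C@H]1CC[C@H](NC(=O)c2ccc(-n3cncn3)cc2)CC1)[C@H]1CCc2nc(N)sc2C1` carries the change (1H-1,2,4-triazol-1-yl in place of 1H-pyrazol-1-yl on an aromatic carbon). Within the data shown here, the one step that bears on it, a 1.6-fold higher number from compound 1 to compound 2 (0.20 log units; within the scatter), was itself an exchange of one five-membered azole for another and stayed within the scatter, so no step beyond the scatter is expected here either, a 1.2-fold higher number from compound 2 to compound 3 (0.07 log units; within the scatter). Compound 3 is therefore estimated at 3.5 nM, within a range of 1.5 nM to 8 nM.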

Compound 3, inhibition constant: 2.4 nM
Estimate against measurement, compound 3: 1.5-fold (0.16 log units) above, and the stated range covers the measured number.
By their numbers in this assay, from the lowest: compounds 1, 3 and 2 (each within the scatter of the next).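

The 1H-1,2,4-triazol-1-yl group reads level with both other azoles in this assay (a 1.3-fold lower number from compound 2 to compound 3 (0.10 log units; within the scatter); a 1.3-fold higher number from compound 1 to compound 3 (0.10 log units; within the scatter)). Three different five-membered azole rings now sit on this aromatic carbon, para to a large group, with all three numbers within the scatter of one another, so a third ring nitrogen leaves no readable mark here. Nothing measured here explains this. Still open, going by these compounds, is how this position responds to a group other than an azole, such as an amine, a carboxylic acid or a longer chain.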